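Swapping Dichlorobenzyl for Fluorobenzyl on a Shared Core

The source may hold more compounds than are shown below. What is called first, only, known or untested is meant among the compounds shown, and "the series" means these compounds.

Compound 1 `Nc1cc(N)c2nc(-c3ccccc3)c(NCc3ccc(Cl)c(Cl)c3)nc2c1` gives 46800 nM in a functional assay on Hs-578T cells (Homo sapiens) for inhibition, read by sulforhodamine B assay, with a stated time of 48 h; a lower number here means a stronger inhibitor of growth, a higher number a weaker inhibitor of growth.
Compound 2 `CCOC(=O)[C@H](CCC(=O)O)NC(=O)c1ccc(Sc2nc3cc(N)cc(N)c3nc2-c2ccccc2)cc1` gives 75900 nM in this assay.
Compound 3 `CCOC(=O)[C@H](CCC(=O)O)NC(=O)c1ccc(CNc2nc3cc(N)cc(N)c3nc2-c2ccccc2)cc1` gives < 100000 nM in this assay, which is a limit of the assay rather than a number.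

Compound 1 and compound 2 sit within the usual scatter of each other in this assay, so neither can be called the stronger inhibitor of growth on these numbers. Compound 3 reaches only (the limit of < 100000 nM in this assay, at which 1 of the 3 values shown sits), so it offers no number for comparison. All three compounds carry the same core, shown beside compound 1, and differ only in the group attached to it.

Compound 4 `Nc1cc(N)c2nc(-c3ccccc3)c(NCc3ccc(F)cc3)nc2c1` has not yet been measured. It differs from compound 1 in a single place: 4-fluorophenyl in place of 3,4-dichlorophenyl on a saturated chain carbon bound to a nitrogen on an aromatic ring. Among the measured compounds shown here, no pair of measured compounds shows a step of this kind, so nothing in the data sets its size or direction. The step is expected to be modest, most likely a slight weakening that may not clear the scatter, though a somewhat larger move in either direction would not surprise. In this assay compound 4 is expected to give about 70000 nM, with a likely range from 25000 nM to 200000 nM. The estimated step is a 1.5-fold higher number from compound 1 to compound 4 (0.17 log units; within the scatter).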

Compound 4, concentration for total growth inhibition: < 100000 nM
Compound 4 gave a limit, no number; the forecaster's own chance of this, stated with the estimate: 35%; the middle value is on the limit's open side.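

In this assay compound 4 gives < 100000 nM, which is a limit of the assay and not a number. The step between compound 1 and compound 4 therefore cannot be read, and this limit is a shared one: the limit of < 100000 nM in this assay, at which 2 of the 4 values shown sit.

The compounds shown leave open whether 4-fluorobenzyl in place of 3,4-dichlorobenzyl changes growth inhibition at all, and in which direction.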